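Replacing ethylsulfanyl with chloro in a lipophilicity series

The source may hold more compounds than are shown below. What is called first, only, known or untested is meant among the compounds shown, and "the series" means these compounds.

Of the compounds shown here, three have been measured so far in a physicochemical assay for lipophilicity; a lower number here means a more polar compound, a higher number a more lipophilic compound. Compound 1 `O=[N+]([O-])c1ccccc1-c1ncco1` gives 1.27. Compound 2 `CCSc1ccccc1C1=NC(c2ccccc2)CO1` gives 4.04, and compound 3 `Cc1cccc(C2=NC(c3ccccc3)CO2)c1` gives 4.11. Compound 2 thus stands second highest of the three numbers; its nearest neighbour is compound 3, whose number sits within the usual scatter of it, so the two cannot be told apart, while compound 1 lies far below it, well beyond the scatter.

The next compound, compound 4 `Clc1ccccc1C1=NC(c2ccccc2)CO1`, is not yet measured. It differs from compound 2 in one place only: chloro in place of ethylsulfanyl on an aromatic carbon. Going by the values given here, no pair of measured compounds shows this change, so its size must be judged from the structures alone. The group that leaves carries three heavy atoms, the group that enters only one, and an acceptor is lost as well.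

On that basis compound 4 is expected to come out a little lower than compound 2 in this assay, with a step of about a number 0.34 log units lower from compound 2 to compound 4 (beyond the scatter), close to the edge of the scatter. Compound 4 is therefore estimated at 3.7, within a range from 3.3 to 4.1.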

Compound 4, partition coefficient: 3.56
Compound 4: middle estimate off by 0.14 log units, on the high side; the measured number falls inside the stated range.
By their numbers in this assay, from the lowest: compound 1; then compound 4; then compounds 2 and 3 (each within the scatter of the next).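

With compound 4, the series gains its first measured step between compounds that differ in one place: in this assay, chloro in place of ethylsulfanyl on an aromatic carbon, ortho to a large group, gives a number 0.48 log units lower from compound 2 to compound 4 (beyond the scatter) and so separates the two groups by more than repeat measurements would. The earlier compounds shown here offered no such pair, so they could not show whether the group at this position made a readable difference; this pair shows that it does, at least for these two groups on this shared core. Nothing available so far accounts for the size of the step, which therefore stands as an observation without an explanation.

The compounds shown give this change only once, so it remains open whether the same exchange would give a step of similar size at another place on the ring or on a different core, such as that of compound 1. Also open, on these data alone, is how a methoxy group, an amine or a longer chain such as butylsulfanyl would compare at this position with ethylsulfanyl and chloro.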